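Stereochemical variation of a hydroxylated pipecolic acid scaffold

The compounds below may be only part of what the source reports. "The series", "measured", "known", "first", "only" and "open" are said of these compounds alone.

Among the compounds with values here, compound 2 `O=C(O)[C@H]1NC[C@@H](O)[C@H](O)[C@@H]1O` gives 42% in an assay on isolated protein for inhibition of cytosolic endo-beta-N-acetylglucosaminidase (Homo sapiens), tested at 1000 uM (on this read-out higher numbers stand for more inhibition at the one concentration tested (going by the name of the read-out) and lower numbers for less inhibition), the higher of the two numbers so far; compound 1 `O=C(O)[C@H]1NC[C@@H](O)[C@@H](O)[C@@H]1O` gives 28%. Within the data shown here, the single measured step, a number 14 percentage points higher from compound 1 to compound 2 (beyond the scatter), shows that configuration alone can move the read-out, and the sole basis for that step is the fact that compounds 1 and 2 differ only in the configuration as drawn. Compound 3 `O=C(O)[C@@H]1NC[C@@H](O)[C@@H](O)[C@@H]1O` is the next member; relative to compound 2 the change is the two compounds have the same atoms and bonds and differ only in configuration as drawn: 2 of 4 stereo elements differ; a stereocentre at a saturated ring carbon is drawn S in compound 2 and R in compound 3; a stereocentre at a saturated ring carbon is drawn S in compound 2 and R in compound 3. Two stereocentres invert at once, so the measured step is only a partial guide: it shows the size a single inversion can produce but not the direction a double inversion will take. A modest change in either direction, or none beyond the scatter, is plausible. The expected step from compound 2 to compound 3 is a number 12 percentage points lower from compound 2 to compound 3 (beyond the scatter). For compound 3 the estimate in this assay is 30%, within 10% to 55%.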

Compound 3, a percentage reported as inhibition, at one concentration (the size of the read-out at that concentration, not a potency): 2.1%
Estimate against measurement, compound 3: 27.9 percentage points above, outside the stated range (below it).
By their numbers in this assay, from the lowest: compound 3; then compound 1; then compound 2.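

In this assay, inverting a single stereocentre at a saturated ring carbon can lower the number as well as raise it: the step is a number 25.9 percentage points lower from compound 1 to compound 3 (beyond the scatter), opposite in direction to a number 14 percentage points higher from compound 1 to compound 2 (beyond the scatter). These two steps from compound 1 involve different stereocentres, so the direction of the change depends on which stereocentre is inverted. The double inversion gives a number 39.9 percentage points lower from compound 2 to compound 3 (beyond the scatter), and this drop rests on configuration alone: the fact that compounds 2 and 3 differ only in the configuration as drawn.

From the compounds shown here alone, the effect of inverting each remaining stereocentre alone stays open, as does whether the two inversions in compound 3 act independently. Also open, going by these compounds, is how the read-out would respond if a primary amide or a hydroxymethyl group replaced the carboxylic acid on the core of compound 2.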